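The compounds below may be only part of what the source reports. "The series", "measured", "known", "first", "only" and "open" are said of these compounds alone.

Measured compounds:
Compound 1, `CCCOc1cccnc1-c1ccc(C(=O)Nc2ccc(C(C)(C)C)cc2)cc1` — in a functional assay for antagonist activity at transient receptor potential cation channel subfamily V member 1 (Rattus norvegicus) (on this read-out higher numbers stand for weaker inhibition and lower numbers for stronger inhibition), compound 1 gives 20 nM.
Compound 2, `CC(C)(C)c1ccc(NC(=O)c2ccc(-c3ncccc3N(S(C)(=O)=O)S(C)(=O)=O)cc2)cc1` — in this assay compound 2 gives 0.4 nM.
Compound 3, `CN(C)Cc1cccnc1-c1ccc(C(=O)Nc2ccc(C(C)(C)C)cc2)cc1` — not yet measured in this assay.

Among the measured compounds shown here, compound 2 stands at the lowest number of the two measured, with compound 1 the nearest neighbour and the only one; the single measured step, a 50-fold lower number from compound 1 to compound 2 (1.70 log units; beyond the scatter), is the whole of what is known about this position of the core. Compound 3 differs from compound 2 in one place: (dimethylamino)methyl in place of bis(methylsulfonyl)amino on an aromatic carbon.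

For the measured compounds named here, only the step from compound 1 to compound 2 bears on this change, since it concerns the same position of the shared core, and it was large. Compound 3 loses the bis(methylsulfonyl)amino that went with that step and gains a (dimethylamino)methyl, for which there is no measured comparison. A step back toward the number of compound 1, or beyond it, is therefore expected, and for compound 3 the expected step is a 75-fold higher number from compound 2 to compound 3 (1.88 log units; beyond the scatter). The estimate for compound 3 is 30 nM, with a range from 5 nM to 300 nM.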

Compound 3, half-maximal inhibitory concentration in the transient receptor potential cation channel subfamily V member 1 assay: 234 nM
The estimate for compound 3 lay 7.8-fold (0.89 log units) below the measured number; low and high end bracket the measured number.
By their numbers in the transient receptor potential cation channel subfamily V member 1 assay, from the lowest: compound 2; then compound 1; then compound 3.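

In the transient receptor potential cation channel subfamily V member 1 assay, this position of the shared core separates the three groups widely: (dimethylamino)methyl in place of bis(methylsulfonyl)amino gives a 590-fold higher number from compound 2 to compound 3 (2.77 log units; beyond the scatter). The change is more than a return to the level of the propoxy compound, since the same group in place of propoxy gives a 12-fold higher number from compound 1 to compound 3 (1.07 log units; beyond the scatter). In a physicochemical assay for solubility, at pH 7.4 (a lower number here means a less soluble compound, a higher number a more soluble compound), compound 2 gives 1 ug/mL and compound 3 gives 50 ug/mL. In the physicochemical assay, the exchange of bis(methylsulfonyl)amino for (dimethylamino)methyl moves the other way, so here the loss of inhibition comes with a gain in solubility: the measured solubility of compound 2, 1 ug/mL, and of compound 3, 50 ug/mL, a 50-fold higher number (1.70 log units; beyond the scatter)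

The compounds shown cannot tell whether the weaker inhibition goes with the amine itself or with the carbon linking it to the core, a question that a dimethylamino group directly on the aromatic carbon or a longer chain carrying the amine could address. On these data alone, it also remains open whether a single methylsulfonylamino group would keep the low number of compound 2.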